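A new aryl group on the shared core

The compounds below may be only part of what the source reports. "The series", "measured", "known", "first", "only" and "open" are said of these compounds alone.

compound 1 `O=C(N/N=C/c1cccc(Cl)c1Cl)Nc1cc2c(Nc3ccc(F)c(Cl)c3)ncnc2cc1O[C@H]1CCOC1`: 16900 nM
compound 2 `COc1cc(/C=N/NC(=O)Nc2cc3c(Nc4ccc(F)c(Cl)c4)ncnc3cc2O[C@H]2CCOC2)cc(OC)c1OC`: 31200 nM

In a functional assay on HepG2 cells (Homo sapiens) for cytotoxicity, read by MTT assay, with a stated time of 72 h (a higher number here means a weaker inhibitor, a lower number a stronger inhibitor), compound 2 stands within the scatter of compound 1, so the two cannot be ordered. Compound 3 `O=C(N/N=C/c1ccc(O)cc1O)Nc1cc2c(Nc3ccc(F)c(Cl)c3)ncnc2cc1O[C@H]1CCOC1` carries 2,4-dihydroxyphenyl in place of 3,4,5-trimethoxyphenyl on a carbon with a double bond to nitrogen. For the measured compounds named here, the only measured exchange at this place, a 1.8-fold higher number from compound 1 to compound 2 (0.27 log units; within the scatter), gives no sign of a large effect, so no step beyond the scatter is expected. Going by the values given here, no measured compound carries the entering group, which keeps the expectation loose. The expected step is a 1.4-fold lower number from compound 2 to compound 3 (0.15 log units; within the scatter). For compound 3 the estimated value is 22000 nM, with an expected range of 9000 nM to 50000 nM.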

Compound 3, half-maximal inhibitory concentration: 4530 nM
Compound 3: middle estimate off by 4.9-fold (0.69 log units), on the high side, and the stated range ends above it.
By their numbers in this assay, from the lowest: compound 3; then compounds 1 and 2 (each within the scatter of the next).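

In this assay, the group on a carbon with a double bond to nitrogen now proves able to shift the number: 2,4-dihydroxyphenyl gives a 6.9-fold lower number from compound 2 to compound 3 (0.84 log units; beyond the scatter) and a 3.7-fold lower number from compound 1 to compound 3 (0.57 log units; beyond the scatter). For the compounds shown here, this is the first step at this place beyond the scatter, and the entering group has 2 hydrogen-bond donors where 3,4,5-trimethoxyphenyl has 0. No measurement here explains the difference. The compounds shown leave open whether both hydroxyl groups are needed, and whether a single hydroxyl or an amine on the ring would give a similar step.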